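The source may report more compounds than this note shows. Statements on the series, on what has been measured and on what is new or still open speak of the compounds shown alone.

Working notes on the series. In a functional assay on PC-3 cells (Homo sapiens) for cytotoxicity, read by sulforhodamine B assay (on this read-out lower numbers stand for stronger inhibition of growth and higher numbers for weaker inhibition of growth), compound 1 `COc1cccc(OC)c1OCCNCCOc1ccccc1OCc1ccccc1Cl` gives 17800 nM, the lowest of the two numbers measured; its nearest neighbour is compound 2 `COc1cccc(OC)c1OCCNCCOc1ccccc1OCc1cccc([N+](=O)[O-])c1`, which in this assay gives 38900 nM. Among the measured compounds shown here, the one measured step on this core, a 2.2-fold higher number from compound 1 to compound 2 (0.34 log units; beyond the scatter), swaps the aryl group on the saturated chain carbon bound to an oxygen on an aromatic ring, and lies beyond the scatter but is modest.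

Compound 3 `CCOc1ccc(COc2ccccc2OCCNCCOc2c(OC)cccc2OC)cc1` is not yet measured in this assay. It differs from compound 1 by 4-ethoxyphenyl in place of 2-chlorophenyl on a saturated chain carbon bound to an oxygen on an aromatic ring. For the measured compounds named here, the only step that bears on it is the aryl swap at the same place from compound 1 to compound 2; a change of the same kind and a step of similar modest size, toward a higher number, is expected here. For compound 3 in this assay the expected value is 30000 nM, with a range of 12000 nM to 80000 nM. This estimate means an expected step of a 1.7-fold higher number from compound 1 to compound 3 (0.23 log units; within the scatter).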

Compound 3, concentration for total growth inhibition: 18200 nM
Compound 3: the middle estimate sits 1.6-fold (0.22 log units) above what was measured; the measured number falls inside the stated range.
By their numbers in this assay, from the lowest: compounds 1 and 3 (each within the scatter of the next); then compound 2.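

In this assay, the position on a saturated chain carbon bound to an oxygen on an aromatic ring accepts 4-ethoxyphenyl, with 9 heavy atoms and 1 hydrogen-bond acceptor, in place of 2-chlorophenyl, with 7 heavy atoms and 0 acceptors, and the result is a 1.0-fold higher number from compound 1 to compound 3 (0.01 log units; within the scatter). The modest loss seen with 3-nitrophenyl therefore does not extend to every replacement of 2-chlorophenyl, since the change to 4-ethoxyphenyl gives a 2.1-fold lower number from compound 2 to compound 3 (0.33 log units; beyond the scatter). No measurement available here accounts for this difference among the aryl groups.

The compounds shown leave open whether a carboxylic acid or an amine on this aryl ring would keep the number level with compound 1 or shift it beyond the scatter. They also leave open how a longer chain in place of the benzyl carbon would read at this position.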